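Swapping the aryl group on an aromatic nitrogen

The compounds below may be only part of what the source reports. "The series", "measured", "known", "first", "only" and "open" are said of these compounds alone.

Three compounds built on a shared core have been examined in an ADME assay on L02 cells (Homo sapiens) for antiproliferative activity, read by MTT assay, with a stated time of 48 h; on this read-out lower numbers stand for stronger inhibition and higher numbers for weaker inhibition. Compound 1 `CCOc1ccc(-n2nncc2CN2C(=O)C3(C(C#N)=C(N)Oc4c3c3nc5ccccc5nc3c3ccccc43)c3ccccc32)cc1` reaches only a limit of the assay, > 50000 nM. Compound 2 `N#CC1=C(N)Oc2c(c3nc4ccccc4nc3c3ccccc23)C12C(=O)N(Cc1cnnn1-c1ccc(Cl)c(Cl)c1)c1ccccc12` likewise gives only a limit, > 50000 nM. Because (the limit of > 50000 nM in this assay, at which 2 of the 3 values shown sit), the step that the two limits leave unreadable from compound 1 to compound 2 cannot be read in size, although it concerns the same aryl group on the same aromatic nitrogen. For the measured compounds named here, compound 3 `N#CC1=C(N)Oc2c(N)cc3nc4ccccc4nc3c2C12C(=O)N(Cc1cnnn1-c1cccc(C(F)(F)F)c1)c1ccccc12` is the one compound with a number, giving 38100 nM in this assay, and so it stands alone as the single measured point among the three.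

Compound 4 `Cc1ccc(-n2nncc2CN2C(=O)C3(C(C#N)=C(N)Oc4c(N)cc5nc6ccccc6nc5c43)c3ccccc32)cc1Cl` differs from compound 3 in one place only: 3-chloro-4-methylphenyl in place of 3-(trifluoromethyl)phenyl on an aromatic nitrogen. Going by the values given here, the single measured step at this site gives no readable size, so no measured step offers a usable size for this change, in either direction. The estimated step of a 1.0-fold higher number from compound 3 to compound 4 (0.02 log units; within the scatter) is therefore expected to lie within the usual scatter of this assay. Compound 4 is estimated at 40000 nM, within a range from 18000 nM to 100000 nM, and the assay may well report a limit rather than a number.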

Compound 4, half-maximal inhibitory concentration: > 50000 nM
Compound 4: a limit, no number; the forecaster's own chance of this, stated with the estimate: 40%; middle value at least 1.2-fold (0.09 log units) away from the limit.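

In this assay, placing 3-chloro-4-methylphenyl on the aromatic nitrogen where compound 3 carries 3-(trifluoromethyl)phenyl gives an at least 1.3-fold higher number from compound 3 to compound 4 (0.11 log units; that floor lies within the scatter). For the compounds shown here, this is the first step at this position with any readable size, yet it is only a floor, so it does not establish that the two aryl groups differ by more than the usual scatter. The true size of the step stays hidden because of the upper limit of the assay, which now holds most of the compounds shown: the limit of > 50000 nM in this assay, at which 3 of the 4 values shown sit.

Going by these compounds alone, compound 3, at 38100 nM, remains the only compound with a number, so it is still open whether any group on this aromatic nitrogen can give a clearly lower number in this assay. The compounds shown also do not tell what an aryl ring bearing an amine or a carboxylic acid would do at this position, or what a longer chain in place of the aryl ring would do.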